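From 2,4-dichlorophenyl to isopropyl on a carbonyl carbon

A few compounds are considered here, and "the series" means these few. Any claim that something is new, unique, unknown or untested is made for them only; others in the source may bear on it.

Compound 1 (`COc1cc(/C=C/C(=O)c2cccc(NC(=O)c3cc(Cl)cc(Cl)c3)c2)ccc1O`) gives 17.7 ug/mL
Compound 2 (`COc1cc(/C=C/C(=O)c2cccc(NC(=O)c3ccc(Cl)cc3Cl)c2)ccc1O`) gives 34.4 ug/mL

Among the compounds with values here, both values come from a functional assay on SiHa cells (Homo sapiens) for inhibition (on this read-out lower numbers stand for stronger inhibition and higher numbers for weaker inhibition), and lie within the usual scatter of each other, so on the only two numbers available compound 2 cannot be separated from compound 1. Compound 3 (`COc1cc(/C=C/C(=O)c2cccc(NC(=O)C(C)C)c2)ccc1O`) differs from compound 2 in one place (isopropyl in place of 2,4-dichlorophenyl on a carbonyl carbon), with isopropyl in place of 2,4-dichlorophenyl on a carbonyl carbon. Within the data shown here, the one measured step that bears on this is a 1.9-fold higher number from compound 1 to compound 2 (0.29 log units; within the scatter) and it only exchanges one dichlorophenyl group for another on the same carbonyl carbon. Among the measured compounds shown here, it is a small step and a weak guide, since no measured compound lacks a ring at that place. The data therefore give no direction, and no change beyond the scatter is expected in this assay although a larger move either way remains possible. The expected step is a 1.1-fold lower number from compound 2 to compound 3 (0.06 log units; within the scatter) and the range is kept wide. The estimate for compound 3 is 30 ug/mL with an expected range of 12 ug/mL to 75 ug/mL in this read-out.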

Compound 3, half-maximal inhibitory concentration: 5.96 ug/mL
Compound 3: middle estimate off by 5.0-fold (0.70 log units), on the high side, and the stated range ends above it.
By their numbers in this assay, from the lowest: compound 3; then compounds 1 and 2 (each within the scatter of the next).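

Up to this point the carbonyl carbon had carried only dichlorophenyl groups, and moving the chlorines around them stayed within the scatter. In this assay the change to isopropyl gives a 5.8-fold lower number from compound 2 to compound 3 (0.76 log units; beyond the scatter) and also a 3.0-fold lower number from compound 1 to compound 3 (0.47 log units; beyond the scatter) and both steps lie beyond the scatter, so, among these three compounds, the group on this carbon does shift the number, and a chlorinated aromatic ring there is not required for inhibition of these cells. No measurement shown here explains why the smaller group with no ring, 3 heavy atoms in place of 8, gives the lower number.

Isopropyl removes the ring, the chlorines and most of the heavy atoms in a single change, so the compounds shown leave open which of these differences accounts for the shift. A plain phenyl would test the chlorines alone and a cyclohexyl the aromatic ring alone, while a methyl or a longer chain on the same carbonyl carbon would show whether the number keeps moving as the carbon count changes.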